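This account rests on a few compounds, and the source may have more. Where it says the series, first, only, none or still open, it means among the compounds named here.

Series notes. Within the data shown here, compound 1 `CCCN(CC1CC1)c1nc(C)nc2c(-c3ccc(OC)cc3C)c(C)nn12` and compound 2 `CCC(CC)Nc1nc(C)nc2c(-c3cc(OC)c(OC)cc3Br)c(C)nn12` share a core but differ in several places at once, so no single step between them is defined and only their two values can be set side by side. In an assay on cell membranes for displacement of a labelled ligand from corticotropin-releasing factor receptor 1 (Rattus norvegicus) (on this read-out higher numbers stand for weaker inhibition and lower numbers for stronger inhibition), compound 1 gives 1.96 nM and compound 2 gives 6.08 nM. Compound 2 thus carries the highest of the two numbers, its nearest neighbour being compound 1 with the lower number, a gap that lies beyond the usual scatter.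

Compound 3 `CCN(CC)c1nc(C)nc2c(-c3cc(OC)c(OC)cc3Br)c(C)nn12` has not yet been measured in this assay. Relative to compound 2 the change is: diethylamino in place of (pentan-3-yl)amino on an aromatic carbon. The group that leaves has 1 hydrogen-bond donor; the group that enters has 0 hydrogen-bond donors. Compound 1 also carries a group with 0 hydrogen-bond donors at this place and shows the lower number, but it differs from compound 2 in more than this one place, so no direction can be read from it. For compound 3 the expected step is a 1.2-fold lower number from compound 2 to compound 3 (0.08 log units; within the scatter), small and within the scatter. The estimate for compound 3 in this assay is 5 nM, with a range from 1.5 nM to 20 nM.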

Compound 3, half-maximal inhibitory concentration: 4.06 nM
For compound 3 the middle estimate is 1.2-fold (0.09 log units) above the measured one, and the stated range covers the measured number.
By their numbers in this assay, from the lowest: compound 1; then compounds 3 and 2 (each within the scatter of the next).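

Among these compounds, at the aromatic carbon between two ring nitrogen atoms, the change to diethylamino in place of (pentan-3-yl)amino gives in this assay a 1.5-fold lower number from compound 2 to compound 3 (0.18 log units; within the scatter), the first step that isolates this position. In this single pair, the group that enters has no hydrogen-bond donor, unlike the group that leaves, and the read-out does not move beyond the usual scatter, so a donor at this place is not needed to keep the number in this range on the aryl group shared by compound 2 and compound 3. Nothing available on the series explains the size of this step.

As far as these compounds go, compound 1 differs from compound 2 and compound 3 in more than one place, so steps to it cannot be read, and it remains open whether the same change would stay within the scatter on the aryl group of compound 1. From the compounds shown here alone, it also remains open how a ring amine such as morpholin-4-yl or a longer chain such as dipropylamino would behave at this place.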